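Ortho substituent swap on a diaryl urea helicase inhibitor

This account rests on a few compounds, and the source may have more. Where it says the series, first, only, none or still open, it means among the compounds named here.

Measured so far:
Compound 1, `CCCCc1cn(-c2ccc(NC(=O)Nc3ccc(C)nc3)cc2)nn1`: 1500 nM in an assay on isolated protein for inhibition of ATP-dependent RNA helicase DDX3X (Homo sapiens); a higher number here means a weaker inhibitor, a lower number a stronger inhibitor
Compound 2, `CCCCc1cn(-c2ccc(NC(=O)Nc3ccccc3C(F)(F)F)cc2)nn1`: 400 nM in this assay
Compound 3, `CC(C)Cc1cn(-c2ccc(NC(=O)Nc3ccccc3F)cc2)nn1`: 120 nM in this assay

All three share a urea-linked core, and they differ in the aryl group on the far side of the urea and in the chain on the triazole. Compound 2 stands second highest of the three numbers in this assay. Its nearest neighbour is compound 3, whose number is lower by a margin beyond the usual scatter, and the furthest is compound 1, whose number is higher by a margin also beyond the scatter. None of these pairs differs in only one place, so no single-point step can be read from them.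

Compound 4, `CCCCc1cn(-c2ccc(NC(=O)Nc3ccccc3OC3CCCC3)cc2)nn1`, is the next one to be tested. It differs from compound 2 in a single position: cyclopentyloxy in place of trifluoromethyl on an aromatic carbon. Among the measured compounds shown here, nothing among the measured compounds tells how this change would play out, so the step is expected to be modest and without a clear direction: the change from compound 2 to compound 4 is expected to be a 1.3-fold higher number from compound 2 to compound 4 (0.10 log units; within the scatter), that is, none beyond the scatter. Compound 4 is therefore expected to give about 500 nM in this assay, within a range from 150 nM to 1600 nM.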

Compound 4, half-maximal inhibitory concentration: 140 nM
Beside the measured number, compound 4's estimate is 3.6-fold (0.55 log units) above it, outside the stated range (below it).
By their numbers in this assay, from the lowest: compounds 3 and 4 (each within the scatter of the next); then compound 2; then compound 1.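

Among the compounds shown here, the step of a 2.9-fold lower number from compound 2 to compound 4 (0.46 log units; beyond the scatter) in this assay is the first comparison in this set that differs in one place only, and it shows that the aromatic carbon ortho to a large group responds to a change of substituent. Cyclopentyloxy, which brings one five-membered non-aromatic ring of carbon only and one hydrogen-bond acceptor, is accepted there in place of trifluoromethyl, and the number falls rather than rises even though the entering group has more heavy atoms than the one it replaces. Which feature of this swap accounts for the lower number cannot be told from a single pair, and no measurement shown here offers an explanation.

From the compounds shown here alone, whether methoxy, isopropoxy or cyclohexyloxy would behave like cyclopentyloxy on this aromatic carbon remains open, as does the outcome with an amine or a carboxylic acid in the same place. Also open, going by these compounds, is whether the same exchange would give a step of similar size on a compound carrying the triazole chain of compound 3 rather than that of compound 2.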